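The source may report more compounds than this note shows. Statements on the series, on what has been measured and on what is new or still open speak of the compounds shown alone.

Measured compounds:
compound 1 `CCc1cccc(NC(=O)CSc2nc(Nc3ccccc3)c3ccccc3n2)c1` gives 12400 nM
compound 2 `C=CC(=O)Nc1cccc(NC(=O)CSc2nc(Nc3ccccc3)c3ccccc3n2)c1` gives 10200 nM

Of the compounds shown here, two built on a shared core have been tested in a functional assay on MDA-MB-231 cells (Homo sapiens) for inhibition, read by MTT assay, with a stated time of 72 h; a lower number here means a stronger inhibitor, a higher number a weaker inhibitor. Compound 1 stands at the highest of the two numbers with 12400 nM, and its nearest neighbour is compound 2; the step of a 1.2-fold lower number from compound 1 to compound 2 (0.08 log units; within the scatter) lies within the scatter, so the two cannot be set in order. Compound 3 `O=C(CSc1nc(Nc2ccccc2)c2ccccc2n1)Nc1ccc(Cl)cc1Cl` has not yet been measured. It differs from compound 1 in one place: 2,4-dichlorophenyl in place of 3-ethylphenyl on an amide-type nitrogen. Going by the values given here, no measured step covers an exchange of 3-ethylphenyl for 2,4-dichlorophenyl. Among the compounds with values here, the only measured step, a 1.2-fold lower number from compound 1 to compound 2 (0.08 log units; within the scatter), did alter the group carried on that amide-type nitrogen, and it stayed within the scatter, which is the sole guide available. On this basis no step beyond the scatter is expected in this assay in either direction, and the step of a 1.2-fold lower number from compound 1 to compound 3 (0.09 log units; within the scatter) is the expected outcome. Compound 3 is therefore estimated at 10000 nM, with an expected range from 3000 nM to 40000 nM.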

Compound 3, half-maximal inhibitory concentration: 19400 nM
The estimate for compound 3 lay 1.9-fold (0.29 log units) below the measured number; measured number inside the range.
By their numbers in this assay, from the lowest: compounds 2, 1 and 3 (each within the scatter of the next).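

Going by these compounds alone, with 2,4-dichlorophenyl on the amide-type nitrogen, compound 3 adds a third group at this position in this assay, and it is the first of the three that carries chlorine and has no substituent containing a carbon chain. Its exchange for 3-ethylphenyl gives a step (a 1.6-fold higher number from compound 1 to compound 3 (0.19 log units; within the scatter)), and its exchange for 3-((vinylcarbonyl)amino)phenyl also gives a step (a 1.9-fold higher number from compound 2 to compound 3 (0.28 log units; within the scatter)), so neither change moves the number beyond the scatter and the three compounds cannot be set in a firm order. No supporting information is available that would account for these results.

The three compounds shown leave open whether any group on the aromatic ring at this position can produce a step beyond the scatter in this assay, for instance an amine, a carboxylic acid or a longer chain such as hexyl. They also leave open how the number would respond to replacing that whole aromatic ring, or to any change in the shared core, since every comparison here concerns the group on the amide-type nitrogen alone.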